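Swapping bromo for fluoro on the methoxy analogue

The source may report more compounds than this note shows. Statements on the series, on what has been measured and on what is new or still open speak of the compounds shown alone.

Three measured compounds share one core. Compound 2 `CCOc1ccc(Br)cc1C(C)NC(=O)NS(=O)(=O)c1ccc(Cl)cc1` gives 171000 nM in a functional assay on thoracic aorta (Rattus norvegicus, strain Wistar), with a stated time of 15 min; a lower number here means that less compound is needed, a higher number that more compound is needed for the effect. Compound 3 `COc1ccc(Br)cc1C(C)NC(=O)NS(=O)(=O)c1ccc(Cl)cc1` gives 80900 nM in this assay; the step of a 2.1-fold lower number from compound 2 to compound 3 (0.33 log units; beyond the scatter) follows the change (hydrogen in place of methyl on a saturated chain carbon bound to an oxygen on an aromatic ring), which is how the two cores differ. Compound 1 `CCOc1ccc(F)cc1C(C)NC(=O)NS(=O)(=O)c1ccc(Cl)cc1` reaches only a limit of this assay, > 300000 nM. That step, an at least 1.7-fold higher number from compound 2 to compound 1 (0.24 log units; that floor lies within the scatter), comes from fluoro in place of bromo on an aromatic carbon and is bounded by the limit of > 300000 nM in this assay, at which 1 of the 3 values shown sits. Compound 4 `COc1ccc(F)cc1C(C)NC(=O)NS(=O)(=O)c1ccc(Cl)cc1` is not yet measured and differs from compound 3 by fluoro in place of bromo on an aromatic carbon, the same kind of change, though here the ring carbon sits para to a methoxy group rather than para to an ethoxy group. Compound 4 is expected to need more compound, with a step of about a 3.1-fold higher number from compound 3 to compound 4 (0.49 log units; beyond the scatter) in this assay. Compound 4 is estimated at 250000 nM, between 120000 nM and 600000 nM.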

Compound 4, half-maximal effective concentration: > 300000 nM
Compound 4 was reported as a limit; the forecaster's own chance of this, stated with the estimate: 40%; middle value at least 1.2-fold (0.07 log units) from the limit.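

In this assay, fluoro in place of bromo on the core of compound 3 gives an at least 3.7-fold higher number from compound 3 to compound 4 (0.56 log units; beyond the scatter), a step beyond the usual scatter. Compound 4 gives > 300000 nM, which is a limit of the assay and not a number, so this step has a floor but no known size. The same swap therefore needs more compound on this core, but it cannot be said whether its size carries over from the ethoxy core, and the step between compound 1 and compound 4 cannot be read, as both are limits: the same change on two cores in this assay, an at least 1.7-fold higher number (0.24 log units; that floor lies within the scatter) from compound 2 to compound 1 and an at least 3.7-fold higher number (0.56 log units; beyond the scatter) from compound 3 to compound 4; the limit leaves it open whether they differ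

From the compounds shown here alone, what iodo or a nitrile on that aromatic carbon would give in this assay remains open. So does the effect of a longer chain in place of the ethoxy group.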